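The source may report more compounds than this note shows. Statements on the series, on what has been measured and on what is new or still open speak of the compounds shown alone.

Three small thiourea compounds were tested in a toxicity assay on RAW264.7 cells (Mus musculus) for cytotoxicity, read by MTT assay, with a stated time of 24 h; on this read-out higher numbers stand for lower toxicity in this test and lower numbers for higher toxicity in this test. Compound 1, `COc1cc(NC(=S)Nc2ccccc2)cc(OC)c1OC`, gives 154000 nM. Compound 2, `CCCCNC(=S)NCc1ccccc1`, gives 177000 nM. Compound 3, `O=C(NNC(=S)NCc1ccccc1)c1ccncc1`, gives 93200 nM. On these numbers compound 2 stands together with the other two: neither compound 1 nor compound 3 is separated from it by more than the usual scatter of this kind of measurement, so the three compounds cannot be told apart on this read-out.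

Compound 4, `CCN(CC)C(=S)NCc1ccccc1`, has not yet been measured in this assay. It differs from compound 2 in one place, (diethylamino in place of butylamino on a thiocarbonyl carbon). The same atoms are present in both compounds, only joined differently, and compound 4 loses one hydrogen-bond donor.

For the measured compounds named here, with no measured pair of this kind to draw on, and with the three measured compounds lying so close to one another, a step beyond the scatter from compound 2 to compound 4 is not expected. The step from compound 2 to compound 4 in this assay is estimated at a 1.0-fold lower number from compound 2 to compound 4 (0.02 log units; within the scatter). Compound 4 is therefore expected to give about 170000 nM, within a range from 80000 nM to 350000 nM.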

Compound 4, half-maximal cytotoxic concentration: >= 200000 nM
Compound 4: only a limit was reported (the forecaster's own chance of this, stated with the estimate: 20%); middle value at least 1.1-fold (0.07 log units) from the limit.
By their numbers in this assay, from the lowest: compounds 3, 1 and 2 (each within the scatter of the next). At a limit, above all of these: compound 4.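

For the compounds shown here, this pair is the first in the set to differ in one place, and it isolates a single change on a thiocarbonyl carbon: diethylamino in place of butylamino, with the same atoms but without the hydrogen-bond donor of butylamino. In this assay, the change gives an at least 1.1-fold higher number from compound 2 to compound 4 (0.05 log units; that floor lies within the scatter), so only a floor is known for this step, and nothing here links the loss of that donor to higher toxicity in this test. The result for compound 4 is a limit, not a number: the limit of >= 200000 nM in this assay, at which 1 of the 4 values shown sits.

On these data alone, it remains open whether another amine at this place, such as morpholine, or a longer chain, such as octylamino, would move the number beyond the scatter from compound 2. The same swap could also behave differently on the other cores shown here.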